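The source may hold more compounds than are shown below. What is called first, only, known or untested is meant among the compounds shown, and "the series" means these compounds.

Three compounds share one core and differ only in the aryl group carried by the five-membered ring. In a functional assay on BJAB cells (Homo sapiens) for antiproliferative activity, with a stated time of 4 days (on this read-out higher numbers stand for an effect only at larger amounts of compound and lower numbers for an effect already at smaller amounts), compound 1 `COc1cc(-c2c(C)nn(-c3nc(-c4ccc(Cl)c(Cl)c4)c(SC(C)C)s3)c2C(=O)O)cc(C(F)(F)F)c1` gives 1380 nM. In this assay compound 2 `Cc1nn(-c2nc(-c3ccc(Cl)c(Cl)c3)c(SC(C)C)s2)c(C(=O)O)c1-c1cccc(C(F)(F)F)c1` gives 22000 nM, and compound 3 `Cc1nn(-c2nc(-c3ccc(Cl)c(Cl)c3)c(SC(C)C)s2)c(C(=O)O)c1-c1cccc(Cl)c1C` gives 5100 nM. Compound 3 thus holds the middle place among the three numbers, with compound 1 below it and compound 2 above it.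

Compound 4 `COc1ccccc1-c1c(C)nn(-c2nc(-c3ccc(Cl)c(Cl)c3)c(SC(C)C)s2)c1C(=O)O` has not yet been measured. It changes compound 3 as follows: 2-methoxyphenyl in place of 3-chloro-2-methylphenyl on an aromatic carbon. Going by the values given here, two measured steps bear on this change. The step of a 16-fold higher number from compound 1 to compound 2 (1.20 log units; beyond the scatter) shows that replacing a methoxy group by hydrogen raised the number strongly, so a methoxy group on this ring went with a lower number in that one case; compound 1, however, also carried a trifluoromethyl group, and its methoxy sat in a 3-methoxy-5-(trifluoromethyl)phenyl group rather than a 2-methoxyphenyl group. The step of a 4.3-fold lower number from compound 2 to compound 3 (0.63 log units; beyond the scatter) shows that exchanging one aryl pattern for another moved the number only modestly. Compound 4 gains a methoxy group while giving up both the chlorine and the methyl of compound 3, so only a small expected step, a 1.3-fold lower number from compound 3 to compound 4 (0.11 log units; within the scatter), is anticipated. Compound 4 is estimated at 4000 nM, with a range from 1000 nM to 20000 nM.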

Compound 4, half-maximal effective concentration: 14700 nM
Compound 4: middle estimate off by 3.7-fold (0.57 log units), on the low side; the range from low to high includes it.
By their numbers in this assay, from the lowest: compound 1; then compound 3; then compounds 4 and 2 (each within the scatter of the next).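

In this assay a methoxy group on this aryl ring does not bring a low number by itself: putting 2-methoxyphenyl in place of 3-chloro-2-methylphenyl gives a 2.9-fold higher number from compound 3 to compound 4 (0.46 log units; beyond the scatter) rather than any gain. Exchanging 3-(trifluoromethyl)phenyl for 2-methoxyphenyl gives a 1.5-fold lower number from compound 2 to compound 4 (0.18 log units; within the scatter) and stays within the usual scatter, so these two aryl groups cannot be told apart on this read-out, even though one carries trifluoromethyl and the other methoxy. The 3-methoxy-5-(trifluoromethyl)phenyl group stays clearly apart, with an 11-fold higher number from compound 1 to compound 4 (1.03 log units; beyond the scatter) as the step, so among these four compounds the lowest number goes with methoxy and trifluoromethyl together on one ring, not with either group alone.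

Nothing shown here gives a reason for these differences. Still open, on these data alone, is whether the low number of compound 1 depends on both groups being present or on where they sit on the ring, and what an amine or a nitrile on this aryl ring would do to the number.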